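Notes on amino for methyl on the benzyl ring

A few compounds are considered here, and "the series" means these few. Any claim that something is new, unique, unknown or untested is made for them only; others in the source may bear on it.

The series rests on a shared core, carried unchanged in compound 1 `COc1ccc(CNc2cc(OC)c(OC)c(OC)c2)cc1C`, compound 2 `C/C=C/C(=O)N(Cc1ccc(OC)c(C)c1)c1cc(OC)c(OC)c(OC)c1` and compound 3 `COc1ccc(CNc2cc(OC)c(OC)c(OC)c2)cc1F`. In a functional assay on HCT-116 cells (Homo sapiens) for inhibition, read by MTT assay, with a stated time of 48 h (on this read-out higher numbers stand for weaker inhibition and lower numbers for stronger inhibition), compound 1 gives 60900 nM, compound 2 gives 23500 nM and compound 3 gives 32200 nM. Compound 2 stands lowest of the three numbers; the step of a 2.6-fold lower number from compound 1 to compound 2 (0.41 log units; beyond the scatter) is modest, while compound 3 sits so close to compound 2 that the two cannot be ordered. Exchanging fluoro for methyl on the aromatic carbon, a 1.9-fold lower number from compound 1 to compound 3 (0.28 log units; within the scatter), stayed within the scatter.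

Compound 4 `C/C=C/C(=O)N(Cc1ccc(OC)c(N)c1)c1cc(OC)c(OC)c(OC)c1` is not yet measured. It differs from compound 2 by amino in place of methyl on an aromatic carbon, a change on an aromatic carbon of a six-membered aromatic ring of carbon only, ortho to a methoxy group and meta to a large group. Within the data shown here, no measured step exchanges methyl for amino. Among the measured compounds shown here, the only step at a related place, fluoro for methyl from compound 1 to compound 3, stayed within the scatter, so no step beyond the scatter is expected here, estimated as a 1.2-fold lower number from compound 2 to compound 4 (0.07 log units; within the scatter). Compound 4 is therefore expected to give about 20000 nM in this assay, within the range 8000 nM to 50000 nM.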

Compound 4, half-maximal inhibitory concentration: 300 nM
Compound 4: middle estimate off by 67-fold (1.82 log units), on the high side; the measured number lies below the stated range.
By their numbers in this assay, from the lowest: compound 4; then compounds 2, 3 and 1 (each within the scatter of the next, the first and the last beyond it).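

In this assay, the aromatic carbon ortho to a methoxy group proves highly sensitive to the group it carries: amino in place of methyl gives a 78-fold lower number from compound 2 to compound 4 (1.89 log units; beyond the scatter), a large step, whereas fluoro in place of methyl gave only a 1.9-fold lower number from compound 1 to compound 3 (0.28 log units; within the scatter), within the scatter. The fluoro step therefore did not reveal how much this position can matter, although it was read on a compound without the (prop-1-en-1-yl)carbonyl on the nitrogen and so is not a direct comparison with the amino step. The exchange replaces a methyl, with no hydrogen-bond donor or acceptor, by an amino group with one of each, but no measurement shown here accounts for the size of the step.

The compounds shown leave open whether the amino group would give a step of similar size on the core of compound 1, with a hydrogen in place of the (prop-1-en-1-yl)carbonyl on the nitrogen. They also leave open whether a hydroxyl, a methylamino or an acetylamino group on this carbon would keep the number as low as compound 4 gives it, at 300 nM.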